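Piperazine for pyrrolidine on a flavone side chain

A few compounds are considered here, and "the series" means these few. Any claim that something is new, unique, unknown or untested is made for them only; others in the source may bear on it.

Measured compounds:
compound 1 `CN1CCN(CCCCOc2c(O)cc3oc(-c4ccccc4)cc(=O)c3c2O)CC1` — > 100000 nM
compound 2 `O=c1cc(-c2ccccc2)oc2cc(O)c(OCCCCN3CCCC3)c(O)c12` — 51000 nM
compound 3 `COc1cc2oc(-c3ccccc3)cc(=O)c2c(O)c1OCCCN1CCCC1` — 6000 nM

Three flavones carrying a basic amine on an ether chain were tested in a functional assay on A549 cells (Homo sapiens) for antiproliferative activity, read by MTT assay, with a stated time of 48 h; on this read-out higher numbers stand for weaker inhibition and lower numbers for stronger inhibition. Compound 1 gives only a limit of the assay, > 100000 nM (the limit of > 100000 nM in this assay, at which 1 of the 3 values shown sits). In this assay compound 2 gives 51000 nM, and compound 3 gives 6000 nM, the lower of the two numbers; compound 3 sits at an at least 1.9-fold higher number from compound 2 to compound 1 (0.29 log units; that floor lies within the scatter) from compound 2 on the other side, and the gap between compound 3 and compound 2 is beyond the scatter. How the cores of compound 3 and compound 2 differ is not broken down here.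

Compound 2 and compound 1 differ by 4-methylpiperazin-1-yl in place of pyrrolidin-1-yl on a saturated chain carbon, four bonds along the chain from an oxygen on an aromatic ring, and that step read an at least 1.9-fold higher number from compound 2 to compound 1 (0.29 log units; that floor lies within the scatter). Compound 4 `COc1cc2oc(-c3ccccc3)cc(=O)c2c(O)c1OCCCN1CCN(C)CC1` is not yet measured; it differs from compound 3 by 4-methylpiperazin-1-yl in place of pyrrolidin-1-yl on a saturated chain carbon, three bonds along the chain from an oxygen on an aromatic ring. The same groups leave and enter, but the place lines differ: three bonds along the chain from the aromatic oxygen in compound 4, four bonds in compound 1, so this is the same kind of change, not the same one.

Resting on the step from compound 2 to compound 1, a modest rise in the number is expected from compound 3 to compound 4, about a 2.0-fold higher number from compound 3 to compound 4 (0.30 log units; within the scatter). Compound 4 is therefore estimated at 12000 nM, with a range from 5000 nM to 40000 nM.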

Compound 4, half-maximal inhibitory concentration: 18000 nM
Estimate against measurement, compound 4: 1.5-fold (0.18 log units) below, within the range that was stated.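

In this assay, 4-methylpiperazin-1-yl in place of pyrrolidin-1-yl gives a 3.0-fold higher number from compound 3 to compound 4 (0.48 log units; beyond the scatter) on this core, so here the change clearly weakens inhibition, though the step is modest. On the other core, compound 1 stands at > 100000 nM as a limit of the assay and not a number. The two steps therefore agree at most in direction: only the newer step is beyond the scatter, the floor of the earlier one lies within it, and nothing shows that the change carries the same size from one core to the other, since the true value of compound 1 could lie anywhere past its limit: the same change on two cores in this assay, an at least 1.9-fold higher number (0.29 log units; that floor lies within the scatter) from compound 2 to compound 1 and a 3.0-fold higher number (0.48 log units; beyond the scatter) from compound 3 to compound 4; the limit leaves it open whether they differ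

With only two pairs, both built on these two amines, the compounds shown leave open whether the rise would hold on any further core in the series, or on a chain of another length with the rest of the molecule held the same. They also leave open how a piperidine, a morpholine or a piperazine without the methyl group would read in place of pyrrolidin-1-yl on either core.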